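The source may hold more compounds than are shown below. What is called first, only, known or untested is meant among the compounds shown, and "the series" means these compounds.

Compound 1 `Cn1nc2c(=O)n(CC3(O)CCN(Cc4ccc(-c5cnco5)cc4Cl)CC3)cnc2c1-c1ccc(CN)cc1` is the starting point of this step. In an assay on isolated protein for inhibition of ubiquitin carboxyl-terminal hydrolase 7 (Homo sapiens), with stated times of 30 min and 2 h (on this read-out higher numbers stand for weaker inhibition and lower numbers for stronger inhibition), compound 1 gives 71.6 nM, the second highest of the three numbers in hand: compound 2 `Cn1nc2c(=O)n(CC3(O)CCN(Cc4ccc(-c5ccco5)cc4Cl)CC3)cnc2c1-c1ccc(OC(F)F)cc1` gives 179 nM, and compound 3 `CCNCc1ccc(-c2c3ncn(CC4(O)CCN(Cc5ccc(-c6ccco6)cc5Cl)CC4)c(=O)c3nn2C)cc1` gives 15.2 nM. Going by the values given here, the one single-place step measured so far, a 12-fold lower number from compound 2 to compound 3 (1.07 log units; beyond the scatter), changes a group elsewhere on the shared core and so says nothing about the change at hand. Compound 4 `Cn1nc2c(=O)n(CC3(O)CCN(Cc4ccc(-n5cccn5)cc4Cl)CC3)cnc2c1-c1ccc(CN)cc1` differs from compound 1 by 1H-pyrazol-1-yl in place of 1,3-oxazol-5-yl on an aromatic carbon. Among the compounds with values here, no measured step bears on this swap, so the expected step is a 1.0-fold higher number from compound 1 to compound 4 (0.02 log units; within the scatter), an estimate that stays within the scatter. The estimate for compound 4 in this assay is 75 nM, within a range of 30 nM to 190 nM.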

Compound 4, half-maximal inhibitory concentration: 233 nM
Compound 4: middle estimate off by 3.1-fold (0.49 log units), on the low side; the whole stated range lies below it.
By their numbers in this assay, from the lowest: compound 3; then compound 1; then compounds 2 and 4 (each within the scatter of the next).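

Replacing 1,3-oxazol-5-yl with 1H-pyrazol-1-yl on this aromatic carbon, para to a large group, gives a 3.3-fold higher number from compound 1 to compound 4 (0.51 log units; beyond the scatter). This position therefore distinguishes between two five-membered aromatic rings with matching heavy-atom, hetero-atom and acceptor counts. No measurement shown accounts for the difference. Going by these compounds, it remains open whether a 1,3-thiazol-5-yl or 1H-imidazol-1-yl ring here would track compound 1 or compound 4. On these data alone, it is also open whether the step carries over to a core bearing the (ethylamino)methyl group of compound 3.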